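Shortening the urea side chain of compound 1

The source may report more compounds than this note shows. Statements on the series, on what has been measured and on what is new or still open speak of the compounds shown alone.

Going by the values given here, in a functional assay on MCF7 cells (Homo sapiens) for cytotoxicity, read by MTT assay, with a stated time of 72 h (on this read-out lower numbers stand for stronger inhibition and higher numbers for weaker inhibition), compound 1 (`COc1ncc(-c2ccc3nc(NC(=O)NCCN4CCCCC4)nn3c2)cc1NS(=O)(=O)c1ccc(F)cc1`) gives 200 nM, the lower of the two numbers so far. Compound 2 (`CCN(CC)CCNC(=O)Nc1nc2ccc(-c3cnc(OC)c(NS(=O)(=O)c4ccc(Cl)cc4)c3)cn2n1`) gives 680 nM, a gap beyond the scatter. Compound 3 (`CNC(=O)Nc1nc2ccc(-c3cnc(OC)c(NS(=O)(=O)c4ccc(F)cc4)c3)cn2n1`) departs from compound 1 by hydrogen in place of (piperidin-1-yl)methyl on a saturated chain carbon bound to an amide-type nitrogen, so 2-(piperidin-1-yl)ethyl becomes methyl. Among the compounds with values here, no measured pair isolates this change. A moderate move towards a higher number is expected, the estimated 4.0-fold higher number from compound 1 to compound 3 (0.60 log units; beyond the scatter). For compound 3 the estimate is 800 nM, with an expected range of 150 nM to 4000 nM.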

Compound 3, half-maximal inhibitory concentration: 250 nM
Compound 3: middle estimate off by 3.2-fold (0.51 log units), on the high side, and the stated range covers the measured number.
By their numbers in this assay, from the lowest: compounds 1 and 3 (each within the scatter of the next); then compound 2.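

In this assay the change from 2-(piperidin-1-yl)ethyl to methyl reads as a 1.3-fold higher number from compound 1 to compound 3 (0.10 log units; within the scatter). For this pair, the (piperidin-1-yl)methyl group with its six-membered non-aromatic ring can therefore leave without a step beyond the scatter, so the ring is not required for the number on the core of compound 1. No data at hand explain this result.

Open, as far as these compounds go, is how a carboxylic acid, a morpholine ring or a longer chain at this place would read against compound 3. Also open, from the compounds shown here alone, is whether methyl gives a similar step on other sulfonamide aryl groups.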